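A few compounds are considered here, and "the series" means these few. Any claim that something is new, unique, unknown or untested is made for them only; others in the source may bear on it.

Measured so far:
compound 1, `COc1ccc2[nH]c(C(=O)N3CC(=O)N(Cc4ccccc4)[C@@H](N4[C@H](C)CCC[C@@H]4C)C3)cc2c1` — 0.112 h
compound 2, `COc1ccc2[nH]c(C(=O)N3CC(=O)N(Cc4cccc(OC(F)F)c4)[C@@H](CN4CCCCC4)C3)cc2c1` — 0.317 h

Compound 1 gives 0.112 h in an ADME assay on microsomes from liver (Homo sapiens) for metabolic stability, with a stated time of 30 min, tested at 1 uM (a lower number here means that the compound disappears faster, a higher number that the compound lasts longer), the lower of the two numbers. Compound 2 gives 0.317 h in this assay. It differs from compound 1 in several places, and the gap between the two numbers lies beyond the scatter. Within the data shown here, no single-change step between measured compounds is available.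

Compound 3, `COc1ccc2[nH]c(C(=O)N3CC(=O)N(Cc4ccccc4)[C@@H](CN4CCCc5ccccc54)C3)cc2c1`, carries (1,2,3,4-tetrahydroquinolin-1-yl)methyl in place of 2,6-dimethylpiperidin-1-yl on a saturated ring carbon; that is, (1,2,3,4-tetrahydroquinolin-1-yl)methyl in place of 2,6-dimethylpiperidin-1-yl on a saturated ring carbon. The comparison with compound 2 is not clean, so its higher value is only weak support for a rise. For compound 3 a small upward step in this assay is expected, probably within the scatter, as a 1.4-fold higher number from compound 1 to compound 3 (0.15 log units; within the scatter). The half-life of compound 3 in this assay is estimated at 0.16 h, with a range of 0.06 h to 0.45 h.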

Compound 3, half-life: 0.183 h
Compound 3: the middle estimate sits 1.1-fold (0.06 log units) below what was measured; the measured number falls inside the stated range.
By their numbers in this assay, from the lowest: compounds 1, 3 and 2 (each within the scatter of the next, the first and the last beyond it).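

The position on a saturated ring carbon, next to the ring nitrogen, now has its first single-change reading in this assay: a 1.6-fold higher number from compound 1 to compound 3 (0.21 log units; within the scatter) with (1,2,3,4-tetrahydroquinolin-1-yl)methyl in place of 2,6-dimethylpiperidin-1-yl. This exchange brings in a six-membered aromatic ring and removes the 2 defined stereocentres of the leaving group, yet the half-life does not shift beyond the usual scatter, so this pair shows no clear sensitivity to the change. No measurement at hand accounts for this step.

Because the aromatic ring and the methyl link enter together, the pair cannot separate their contributions. On these data alone, how the half-life responds at this position to a morpholine or a carboxylic acid remains open.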